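Nitro Replaces Fluorine on the Benzyl Arm

The source may hold more compounds than are shown below. What is called first, only, known or untested is meant among the compounds shown, and "the series" means these compounds.

Compound 1 `Cc1ccc(Cn2cc(COc3ccc4c(=O)ccoc4c3)nn2)cc1` and compound 2 `O=c1ccoc2cc(OCc3cn(Cc4ccccc4F)nn3)ccc12` share one core and differ only in the ring on a saturated chain carbon bound to an aromatic nitrogen. In a functional assay on A549 cells (Homo sapiens) for cytotoxicity, read by MTT assay, with a stated time of 48 h (on this read-out lower numbers stand for stronger inhibition and higher numbers for weaker inhibition), compound 1 gives 50700 nM, while compound 2 gives 10800 nM, the lower of the two numbers measured, the step being a 4.7-fold lower number from compound 1 to compound 2 (0.67 log units; beyond the scatter). Compound 3 `O=c1ccoc2cc(OCc3cn(Cc4ccc([N+](=O)[O-])cc4)nn3)ccc12` carries 4-nitrophenyl in place of 2-fluorophenyl on a saturated chain carbon bound to an aromatic nitrogen. Among the compounds with values here, only that single earlier step bears on this change; it shows that the group in this place can shift the number modestly, but the direction here is unknown. Compound 3 is therefore expected to give 12000 nM, within 4000 nM to 40000 nM. The expected step is a 1.1-fold higher number from compound 2 to compound 3 (0.05 log units; within the scatter).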

Compound 3, half-maximal inhibitory concentration: > 100000 nM
Compound 3 was reported as a limit; the forecaster's own chance of this, stated with the estimate: 5%; middle value at least 8.3-fold (0.92 log units) from the limit.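

The value of compound 3 in this assay is a limit, not a number: the limit of > 100000 nM in this assay, at which 1 of the 3 values shown sits.

Putting 4-nitrophenyl in place of 2-fluorophenyl gives an at least 9.2-fold higher number from compound 2 to compound 3 (0.96 log units; beyond the scatter), so changing this ring can raise the number as well as lower it. Nitro in place of methyl on an aromatic carbon gives an at least 1.9-fold higher number from compound 1 to compound 3 (0.29 log units; that floor lies within the scatter), and that floor does not separate the two compounds.

Still open, going by these compounds, is whether the rise follows the nitro group itself or where it sits on the ring. On these data alone, how a 4-aminophenyl or a 4-fluorophenyl ring would read here also remains open.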